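A methoxy swap on compound 3: what to expect

The source may hold more compounds than are shown below. What is called first, only, known or untested is meant among the compounds shown, and "the series" means these compounds.

compound 1 `COc1cc2oc(-c3cccc(NC(=O)c4ccc(Cl)cc4)c3)cc(=O)c2c(OC)c1OC`: 21300 nM
compound 2 `COc1cc2oc(-c3cccc(NC(=O)c4ccc(F)cc4)c3)cc(=O)c2c(OC)c1OC`: 47200 nM
compound 3 `COc1cc2oc(-c3cccc(NC(=O)c4ccc(C(F)(F)F)cc4)c3)cc(=O)c2c(OC)c1OC`: 61100 nM

All three compounds were tested in a functional assay on HepG2 cells (Homo sapiens) for inhibition, read by MTT assay; on this read-out higher numbers stand for weaker inhibition of growth and lower numbers for stronger inhibition of growth. Compound 3 belongs to the upper end of these numbers, with a 2.9-fold higher number from compound 1 to compound 3 (0.46 log units; beyond the scatter), and with a 1.3-fold higher number from compound 2 to compound 3 (0.11 log units; within the scatter).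

The next compound, compound 4 `COc1ccccc1C(=O)Nc1cccc(-c2cc(=O)c3c(OC)c(OC)c(OC)cc3o2)c1`, has not yet been measured. The change is 2-methoxyphenyl in place of 4-(trifluoromethyl)phenyl on a carbonyl carbon. In words, 2-methoxyphenyl stands in place of 4-(trifluoromethyl)phenyl on a carbonyl carbon.

Among the measured compounds shown here, no measured step makes this exact swap, and no measured compound carries 2-methoxyphenyl. The closest evidence is the exchange of one group for another at the same place, which gave a 2.2-fold higher number from compound 1 to compound 2 (0.35 log units; beyond the scatter). These steps were modest or smaller, so a small step is expected here, though its direction is poorly supported. Compound 1 at 21300 nM marks the low end of the measured numbers, so the estimate is placed inside the measured span. The expected step is a 1.5-fold lower number from compound 3 to compound 4 (0.16 log units; within the scatter). For compound 4 the estimated value is 42000 nM, with an expected range from 16000 nM to 100000 nM.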

Compound 4, concentration for 50% growth inhibition: 7530 nM
Estimate against measurement, compound 4: 5.6-fold (0.75 log units) above; measured number outside the range, below it.
By their numbers in this assay, from the lowest: compound 4; then compound 1; then compounds 2 and 3 (each within the scatter of the next).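

In this assay the 2-methoxyphenyl on the carbonyl carbon gives the lowest number of the four compounds, with an 8.1-fold lower number from compound 3 to compound 4 (0.91 log units; beyond the scatter) and a 6.3-fold lower number from compound 2 to compound 4 (0.80 log units; beyond the scatter) and also a 2.8-fold lower number from compound 1 to compound 4 (0.45 log units; beyond the scatter) in this short series. The earlier groups, 4-chlorophenyl, 4-fluorophenyl and 4-(trifluoromethyl)phenyl, moved the number only modestly, whereas this change shows that the group on the carbonyl carbon can move growth inhibition further, and towards stronger inhibition. No measured evidence explains why this group does better.

The new group differs from the earlier ones in both its substituent and the number of that substituent's place on the phenyl ring, so the compounds shown cannot separate these two changes. A 4-methoxyphenyl or a plain phenyl group would help to separate them, and a 2-aminophenyl group would test whether the methoxy oxygen can be exchanged.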